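The compounds below may be only part of what the source reports. "The series", "measured", "known", "first", "only" and "open" are said of these compounds alone.

Measured compounds:
compound 1 `CC(=O)N1c2ccccc2CCC1C(=O)Nc1ccccc1O`, 89600 nM
compound 2 `CCCC(=O)N1c2ccccc2CCC1C(=O)Nc1ccccc1C(F)(F)F`, > 70000 nM
compound 3 `O=C(Nc1cc(C(F)(F)F)cc(C(F)(F)F)c1)C1CCc2ccccc2N1`, 8270 nM

The study reads growth inhibition in a functional assay on MDA-MB-231 cells (Homo sapiens) for cytotoxicity, read by sulforhodamine B assay, with a stated time of 72 h; a higher number here means a weaker inhibitor of growth, a lower number a stronger inhibitor of growth. Compound 1 gives 89600 nM in this assay, the highest of the two numbers reported; the nearest number comes from compound 3, which gives 8270 nM, a gap that lies beyond the scatter of the assay. Compound 2 is reported only as a limit, (the limit of > 70000 nM in this assay, at which 1 of the 3 values shown sits), so no number stands for it.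

The step under consideration leads from compound 1 to compound 4 `O=C(Nc1ccccc1O)C1CCc2ccccc2N1C(=O)c1cccc(Cl)c1`. The change is 3-chlorophenyl in place of methyl on a carbonyl carbon; cut one bond further out, it reads acetyl to (3-chlorophenyl)carbonyl. Within the data shown here, no step between two measured compounds shares this change, so the size of the step is not fixed by the data. Compound 2, which carries a larger acyl group on the ring nitrogen together with a different anilide, reaches only a limit, while compound 3, which carries no acyl group at all, gives the lower of the two numbers; neither pair forms a clean comparison with compound 4.

Given this, compound 4 is expected to fall near compound 1, with the step from compound 1 to compound 4 estimated as a 2.0-fold lower number from compound 1 to compound 4 (0.30 log units; within the scatter), a change not clearly beyond the scatter in this assay. Compound 4 is thus estimated at 45000 nM, within 10000 nM to 150000 nM.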

Compound 4, concentration for 50% growth inhibition: 10600 nM
Estimate against measurement, compound 4: 4.2-fold (0.63 log units) above; measured number inside the range.
By their numbers in this assay, from the lowest: compounds 3 and 4 (each within the scatter of the next); then compound 1.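

In this assay, placing 3-chlorophenyl in place of methyl on a carbonyl carbon whose other neighbour is an amide-type nitrogen in a ring gives an 8.5-fold lower number from compound 1 to compound 4 (0.93 log units; beyond the scatter), the first step at this position that can be read from the compounds shown. The step shows that this carbonyl carbon accepts a group carrying one six-membered aromatic ring of carbon only, and that the larger group here goes with stronger growth inhibition rather than a loss of it, with the rest of the structure unchanged. Compound 2 adds no number at this position and differs from compound 1 in more than one place, its entry being only a limit: the limit of > 70000 nM in this assay, at which 1 of the 4 values shown sits.

The compounds shown leave open whether the aromatic ring or the chlorine carries this step, a question that a plain phenyl on the same carbonyl carbon would separate. They also leave open how a longer alkyl chain or an amine-bearing group would read here, and whether the same change gives a step of similar size on a different anilide.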